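The compounds below may be only part of what the source reports. "The series", "measured", "known", "first", "only" and "open" are said of these compounds alone.

Measured compounds:
- compound 1, `O=C(OC1(C(=O)Nc2ccc([N+](=O)[O-])cc2)CCCCC1)c1ccc(C(F)(F)F)cc1`: 29.1 nM
- compound 2, `Cc1ccc(C(=O)OC2(C(=O)Nc3ccc([N+](=O)[O-])cc3)CCCCC2)cc1`: 61.2 nM
- compound 3, `O=C(OC1(C(=O)Nc2ccc([N+](=O)[O-])cc2)CCCCC1)c1ccccc1`: 734 nM

In a functional assay on HepG2 cells (Homo sapiens) for inhibition, read by MTT assay, with a stated time of 72 h (a lower number here means a stronger inhibitor, a higher number a weaker inhibitor), compound 3 stands highest of the three numbers. Its nearest neighbour is compound 2, from which a 12-fold higher number from compound 2 to compound 3 (1.08 log units; beyond the scatter), and the furthest is compound 1, from which a 25-fold higher number from compound 1 to compound 3 (1.40 log units; beyond the scatter). Both steps are single changes on the aromatic carbon of the benzoyl group, and both are beyond the scatter.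

Compound 4, `O=C(Nc1ccc([N+](=O)[O-])cc1)C1(O)CCCCC1`, differs from compound 3 as follows: hydrogen in place of benzoyl on an oxygen on a saturated carbon. Among the compounds with values here, no measured step covers this change; the three measured compounds all keep the benzoyl ester and vary only its ring substituent. What the measured steps do show is that each removal on that ring, a 25-fold higher number from compound 1 to compound 3 (1.40 log units; beyond the scatter) and a 12-fold higher number from compound 2 to compound 3 (1.08 log units; beyond the scatter), gave a markedly higher number in this assay. Taking away the whole benzoyl group goes further in the same direction, so a further rise in this assay is expected, probably larger than either measured step, though the pair gives no direct anchor for its size.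

For compound 4 the expected value in this assay is 6000 nM, with a range of 1200 nM to 30000 nM, which would mean an expected step of an 8.2-fold higher number from compound 3 to compound 4 (0.91 log units; beyond the scatter).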

Compound 4, half-maximal inhibitory concentration: 648 nM
Compound 4: the middle estimate sits 9.3-fold (0.97 log units) above what was measured; measured number outside the range, below it.
By their numbers in this assay, from the lowest: compound 1; then compound 2; then compounds 4 and 3 (each within the scatter of the next).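

In this assay, cutting benzoyloxy back to hydroxy gives a 1.1-fold lower number from compound 3 to compound 4 (0.05 log units; within the scatter), so on this oxygen an unsubstituted benzoyl group cannot be told apart from hydrogen. The same exchange starting from the (4-methylphenyl)carbonyl group gives an 11-fold higher number from compound 2 to compound 4 (1.02 log units; beyond the scatter), which shows that at this position the ester counts only once its ring carries a substituent. The earlier steps shown here showed that the methyl and trifluoromethyl groups mattered, but only now is it clear that the plain benzoyl ester stands level with the free hydroxy compound, so the gain in a 25-fold higher number from compound 1 to compound 3 (1.40 log units; beyond the scatter) is not an addition to any contribution from the benzoyl group itself. Nothing at hand explains this result.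

The compounds shown leave open whether a smaller acyl group such as acetyl on this oxygen would behave like benzoyl or like the methyl-bearing ester. They also leave open whether other ring substituents, such as a chlorine atom or a methoxy group, would match methyl and trifluoromethyl, and whether an amine in place of the hydroxy would keep the number of compound 4.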